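This account rests on a few compounds, and the source may have more. Where it says the series, first, only, none or still open, it means among the compounds named here.

Measured in a toxicity assay on MT4 cells (Homo sapiens) for cytotoxicity, read by MTT assay, with a stated time of 5 days; on this read-out higher numbers stand for lower toxicity in this test and lower numbers for higher toxicity in this test:
- compound 1 `Cc1cnc(Nc2ccc(C#N)cc2)nc1Nc1c(F)cc(-c2cncnc2)cc1F`: 900 nM
- compound 2 `Cc1cnc(Nc2ccc(C#N)cc2)nc1Nc1c(F)cc(-c2cccs2)cc1F`: 8000 nM
- compound 3 `Cc1cnc(Nc2ccc(C#N)cc2)nc1Nc1c(F)cc(-c2cncc(C(F)(F)F)c2)cc1F`: 8200 nM

Compound 3 shares the top of this small range with compound 2, the step being a 1.0-fold higher number from compound 2 to compound 3 (0.01 log units; within the scatter). Compound 1 lies clearly lower, with an 8.9-fold higher number from compound 1 to compound 2 (0.95 log units; beyond the scatter) and a 9.1-fold higher number from compound 1 to compound 3 (0.96 log units; beyond the scatter). Next is compound 4 `Cc1cnc(Nc2ccc(C#N)cc2)nc1Nc1c(F)cc(-c2ccc(C#N)nc2)cc1F`, with 6-cyanopyridin-3-yl in place of 5-(trifluoromethyl)pyridin-3-yl on an aromatic carbon. Going by the values given here, no measured step makes this swap. Compound 1, also without trifluoromethyl, gives 900 nM, but compound 2, likewise without it, gives 8000 nM, so the evidence is mixed. A partial move towards a lower number in this assay is expected, smaller than a 9.1-fold higher number from compound 1 to compound 3 (0.96 log units; beyond the scatter). The expected step is a 2.3-fold lower number from compound 3 to compound 4 (0.37 log units; beyond the scatter). For compound 4 the estimated value is 3500 nM, with an expected range of 1000 nM to 10000 nM.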

Compound 4, half-maximal cytotoxic concentration: 62000 nM
Compound 4: middle estimate off by 18-fold (1.25 log units), on the low side; the whole stated range lies below it.
By their numbers in this assay, from the lowest: compound 1; then compounds 2 and 3 (each within the scatter of the next); then compound 4.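

In this assay, 6-cyanopyridin-3-yl gives the highest number of the four, with a 7.6-fold higher number from compound 3 to compound 4 (0.88 log units; beyond the scatter), a 7.8-fold higher number from compound 2 to compound 4 (0.89 log units; beyond the scatter) and a 69-fold higher number from compound 1 to compound 4 (1.84 log units; beyond the scatter). The level reached by thiophen-2-yl and 5-(trifluoromethyl)pyridin-3-yl is therefore no ceiling for this position, and the substituent on the six-membered aromatic ring alone moves the number this far. No available evidence accounts for this step.

Open, on these data alone, is whether the nitrile itself or its place on the ring carries the step. Also open, as far as these compounds go, is whether an amine or a carboxylic acid there would move the number the same way.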